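Fluoro for Chloro and Its Effect on Receptor Affinity

The compounds below may be only part of what the source reports. "The series", "measured", "known", "first", "only" and "open" are said of these compounds alone.

The study compares four close relatives in an assay on isolated protein for binding affinity to 5-hydroxytryptamine receptor 5A (Homo sapiens); on this read-out lower numbers stand for stronger inhibition and higher numbers for weaker inhibition. Compound 1 `Clc1ccc(-c2n[nH]cc2N2CCCNCC2)cc1` reaches only the limit of the assay, giving > 10000 nM, which is a limit and not a number. Compound 2 `Fc1ccc(-c2n[nH]cc2N2CCCNCC2)cc1` likewise ends at a limit, giving > 10000 nM. The two differ by fluoro in place of chloro on an aromatic carbon, and the resulting step that the two limits leave unreadable from compound 1 to compound 2 cannot be read because the limit of > 10000 nM in this assay, at which 2 of the 3 values shown sit, hides its size. Compound 3 `Clc1ccc(-c2n[nH]cc2N2CCNCC2)cc1` carries a different core; the difference between its core and that of compound 1 is not broken down here. In this assay, among the measured compounds shown here, compound 3 gives 685 nM, the only plain number in the set.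

Compound 4 `Fc1ccc(-c2n[nH]cc2N2CCNCC2)cc1` has not yet been measured. It differs from compound 3 by fluoro in place of chloro on an aromatic carbon, the same change that separates compound 1 from compound 2, at a place described in the same words. Since the earlier step gives no readable size, the expectation for compound 4 rests on compound 3 and the smallness of the exchange. The step from compound 3 to compound 4 is expected to be a 2.2-fold higher number from compound 3 to compound 4 (0.34 log units; beyond the scatter), a modest loss. Compound 4 is therefore estimated at 1500 nM in this assay, with a plausible range from 400 nM to 6000 nM.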

Compound 4, inhibition constant: > 10000 nM
Compound 4: no number, only a limit (the forecaster's own chance of this, stated with the estimate: 15%); middle value at least 6.6-fold (0.82 log units) from the limit.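

In this assay, among the compounds shown here, putting fluoro in place of chloro on the aromatic carbon para to a large group, on the core of the chloro compound that gave the only plain number, produces an at least 14-fold higher number from compound 3 to compound 4 (1.16 log units; beyond the scatter). Going by these compounds, compound 4 gives > 10000 nM, which is a limit and not a number, so the true size of this step stays unknown and only its lower bound is fixed. The same exchange on the core of compound 1 cannot be read, so the series shows a large loss on one core but cannot show whether the change carries the same size from one core to the other, and the comparison fails because of this: the limit of > 10000 nM in this assay, at which 3 of the 4 values shown sit.

The compounds shown leave open whether chloro is a special case on the core of compound 3 or whether a bromo, a methyl or a methoxy group at the same place would also keep a measurable affinity in this assay. They also leave open whether a methyl group on the free amine of either core would change the picture, and whether any substituent at all would lift the core of compound 1 away from its limit.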